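Swapping a thiophene for a phenyl on a pyridine core

The source may hold more compounds than are shown below. What is called first, only, known or untested is meant among the compounds shown, and "the series" means these compounds.

Measured compounds:
Compound 1, `Oc1ccc(-c2cc(-c3cccc(Cl)c3)nc(-c3cccs3)c2)cc1`: 2720 nM
Compound 2, `Oc1ccc(-c2cc(-c3ccccc3)nc(-c3ccc(Cl)cc3)c2)cc1`: 4810 nM
Compound 3, `Oc1ccc(-c2cc(-c3ccsc3)nc(-c3cccc(Cl)c3)c2)cc1`: 2670 nM

In an ADME assay on HEK293 cells (Homo sapiens) for cytotoxicity, read by CCK-8 assay and cell counting, with a stated time of 2 days (on this read-out higher numbers stand for weaker inhibition and lower numbers for stronger inhibition), compound 3 gives the smallest of the three numbers, though it sits within the usual scatter of both others: the change a 1.0-fold lower number from compound 1 to compound 3 (0.01 log units; within the scatter) is small, and compound 2 differs from compound 3 in two places, so its value only shows that the two lie within the scatter of each other.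

Compound 4, `Oc1ccc(-c2cc(-c3ccccc3)nc(-c3cccc(Cl)c3)c2)cc1`, has not been measured. Its change from compound 3 is phenyl in place of thiophen-3-yl on an aromatic carbon. Among the measured compounds shown here, no measured step follows exactly this change. For the measured compounds named here, the one measured single step, a 1.0-fold lower number from compound 1 to compound 3 (0.01 log units; within the scatter), exchanged one thiophene for another and stayed within the scatter, and compound 2, which carries a phenyl at this place, gives a number within the scatter of compound 3. The step of a 1.2-fold higher number from compound 3 to compound 4 (0.09 log units; within the scatter) is therefore expected to stay within the scatter. Compound 4 is estimated at 3300 nM, with a likely range from 1600 nM to 6800 nM in this assay.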

Compound 4, half-maximal inhibitory concentration: 2820 nM
For compound 4 the middle estimate is 1.2-fold (0.07 log units) above the measured one; low and high end bracket the measured number.
By their numbers in this assay, from the lowest: compounds 3, 1, 4 and 2 (each within the scatter of the next).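

In this assay, a phenyl ring can take the place next to the ring nitrogen without a readable shift, whether it replaces thiophen-3-yl (a 1.1-fold higher number from compound 3 to compound 4 (0.02 log units; within the scatter)) or thiophen-2-yl (a 1.0-fold higher number from compound 1 to compound 4 (0.02 log units; within the scatter)). The earlier single step only exchanged one thiophene for another, whereas these steps change a five-membered ring with a sulfur atom into a six-membered ring of carbon only. The chlorine's place also makes no readable difference here, with 3-chlorophenyl in place of 4-chlorophenyl (a 1.7-fold lower number from compound 2 to compound 4 (0.23 log units; within the scatter)).

The compounds shown carry only aromatic rings at this place, so what an amine, a carboxylic acid or a longer chain would do there stays open. No further data are at hand to explain why these numbers stay so close.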